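Lengthening the Chain Once More: From Compound 3 to Compound 4

The source may hold more compounds than are shown below. What is called first, only, known or untested is meant among the compounds shown, and "the series" means these compounds.

Measured so far in a functional assay on A549 cells (Homo sapiens) for inhibition, read by CCK-8 assay, with a stated time of 72 h, tested at 1 uM; on this read-out lower numbers stand for a weaker effect and higher numbers for a stronger effect at the one concentration tested:
compound 1 `CN(C)C(=O)c1cc2cnc(Nc3ccc(S(=O)(=O)NCCCCCN=C=S)cc3)nc2n1C1CCCC1` gives 56.6%
compound 2 `CN(C)C(=O)c1cc2cnc(Nc3ccc(C(=O)NCCCN=C=S)cc3)nc2n1C1CCCC1` gives 32.9%
compound 3 `CN(C)C(=O)c1cc2cnc(Nc3ccc(C(=O)NCCCCN=C=S)cc3)nc2n1C1CCCC1` gives 30.2%

Compound 3 carries the lowest number of the three. Its nearest neighbour is compound 2, and that gap, a number 2.7 percentage points lower from compound 2 to compound 3 (within the scatter), lies within the scatter of repeated measurements, so the two cannot be told apart. The gap to compound 1, a number 26.4 percentage points lower from compound 1 to compound 3 (beyond the scatter), lies beyond the scatter.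

Compound 4 `CN(C)C(=O)c1cc2cnc(Nc3ccc(C(=O)NCCCCCN=C=S)cc3)nc2n1C1CCCC1` has not yet been measured. It differs from compound 3 in one place: a group of 4 heavy atoms (2 carbon, 1 nitrogen, 1 sulfur; no ring) in place of a group of 3 heavy atoms (1 carbon, 1 nitrogen, 1 sulfur; no ring), on a saturated chain carbon, four bonds along the chain from an amide-type nitrogen. Going by the values given here, one measured step bears directly on this change, the step of a number 2.7 percentage points lower from compound 2 to compound 3 (within the scatter), which also exchanged a group of 3 heavy atoms for a group of 4 heavy atoms on the same saturated chain and stayed within the scatter. The steps of a number 23.7 percentage points lower from compound 1 to compound 2 (beyond the scatter) and a number 26.4 percentage points lower from compound 1 to compound 3 (beyond the scatter) replace the linking group on the aromatic carbon rather than the chain and do not speak to this change.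

Compound 4 is therefore expected to differ from compound 3 by about a number 0.8 percentage points higher from compound 3 to compound 4 (within the scatter), a step not beyond the scatter in this assay. The estimate for compound 4 in this assay is 31%, with a range from 20% to 43%.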

Compound 4, a percentage reported as inhibition, at one concentration (the size of the read-out at that concentration, not a potency): 29.3%
Compound 4: middle estimate off by 1.7 percentage points, on the high side, and the stated range covers the measured number.
By their numbers in this assay, from the lowest: compounds 4, 3 and 2 (each within the scatter of the next); then compound 1.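

In this assay lengthening the chain that ends in the isothiocyanate again leaves the number within the scatter (a number 0.9 percentage points lower from compound 3 to compound 4 (within the scatter)), and the same holds across the longest extension shown (a number 3.6 percentage points lower from compound 2 to compound 4 (within the scatter)). Among compound 2, compound 3 and compound 4, chain length at this position therefore does not separate one compound from another. Going by these compounds alone, compound 4 also gives the first comparison with compound 1 in which the chain is the same and only the link on the aromatic carbon differs, a carbonyl in place of a sulfonyl, and this single exchange gives a step beyond the scatter (a number 27.3 percentage points lower from compound 1 to compound 4 (beyond the scatter)), so the gap to compound 1 remains with the chain held constant.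

Nothing measured here offers an explanation for either finding.

Going by these compounds, it remains open whether a longer chain would stay within the scatter, and whether a sulfonyl link would give a similar number on the shorter chains. Also open, on these data alone, is how an amine or a carboxylic acid at the end of the chain, in place of the isothiocyanate, would read in this assay.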